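The compounds below may be only part of what the source reports. "The series", "measured", "known", "first", "only" and "open" are said of these compounds alone.

Compound 2 `NS(=O)(=O)CCNc1nonc1/C(=N/O)Nc1ccc(F)c(Br)c1` gives the lowest number among the three measured compounds in an assay on isolated protein for inhibition of Indoleamine 2,3-dioxygenase 1 (Homo sapiens), read by fluorescence, with a stated time of 60 min; on this read-out higher numbers stand for weaker inhibition and lower numbers for stronger inhibition: in this assay compound 2 gives 71 nM. Compound 1 `NS(=O)(=O)NNc1nonc1/C(=N/O)Nc1ccc(F)c(Br)c1` gives 218 nM in this assay, and compound 3 `O=S(=O)(CCNc1nonc1/C(=N/O)Nc1ccc(F)c(Br)c1)NCC1CC1` gives 312 nM. The step of a 3.1-fold lower number from compound 1 to compound 2 (0.49 log units; beyond the scatter) replaces sulfamoylamino with 2-sulfamoylethyl, while the step of a 4.4-fold higher number from compound 2 to compound 3 (0.64 log units; beyond the scatter) puts cyclopropylmethyl on the sulfonamide nitrogen. Compound 4 `NNS(=O)(=O)CCNc1nonc1/C(=N/O)Nc1ccc(F)c(Br)c1` differs from compound 2 by amino in place of hydrogen on a sulfonamide nitrogen. Among the measured compounds shown here, of the two measured steps, the one most like this change is the substitution on the sulfonamide nitrogen seen from compound 2 to compound 3, which raised the number; the change from compound 1 to compound 2 also shows that an extra nitrogen next to the sulfonyl group went with a higher number. Both point the same way, so a step in this assay upward from compound 2, smaller than that to compound 3 since only one heavy atom enters, is expected for compound 4, namely a 2.1-fold higher number from compound 2 to compound 4 (0.32 log units; beyond the scatter). Compound 4 is therefore estimated at 150 nM, with a range from 60 nM to 400 nM.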

Compound 4, half-maximal inhibitory concentration: 135 nM
Estimate against measurement, compound 4: 1.1-fold (0.05 log units) above; the range from low to high includes it.
By their numbers in this assay, from the lowest: compounds 2, 4, 1 and 3 (each within the scatter of the next, the first and the last beyond it).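

In this assay, amino in place of hydrogen on a sulfonamide nitrogen gives a step that stays inside the scatter (a 1.9-fold higher number from compound 2 to compound 4 (0.28 log units; within the scatter)), so this position accepts this one added nitrogen with no change that can be told apart from repeat measurements. The same position does separate substituents, since amino and cyclopropylmethyl differ beyond the scatter (a 2.3-fold lower number from compound 3 to compound 4 (0.36 log units; beyond the scatter)), whereas 2-(aminosulfamoyl)ethyl and sulfamoylamino on the nitrogen on the aromatic ring cannot be told apart (a 1.6-fold lower number from compound 1 to compound 4 (0.21 log units; within the scatter)). Nothing available here accounts for any of these steps.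

From the compounds shown here alone, whether a methyl or a hydroxy group on the sulfonamide nitrogen would read like amino or like cyclopropylmethyl remains open. So does the reading of a dimethylamino group there, or of a propyl chain in place of the ethyl link to the sulfonyl group.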